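Methylamino in place of methylsulfanyl on compound 3

The source may report more compounds than this note shows. Statements on the series, on what has been measured and on what is new or still open speak of the compounds shown alone.

Compound 1, `COC(=O)C1=C(C)N=C(SC)NC1c1cccc([N+](=O)[O-])c1`: 3290 nM
Compound 2, `CSC1=NC(c2cccc([N+](=O)[O-])c2)C(C(=O)OC(C)C)=C(C)N1`: 420 nM
Compound 3, `COC(=O)C1=C(C)N=C(SC)N(C(=O)OC(C)C)C1c1cccc([N+](=O)[O-])c1`: 16100 nM

These three compounds were tested in an assay on HEK293 cells for antagonist activity at Voltage-dependent L-type calcium channel subunit alpha-1C (Oryctolagus cuniculus), read by FLIPR; a lower number here means a stronger inhibitor, a higher number a weaker inhibitor. Compound 3 gives the highest number of the three, so it is the weakest inhibitor of the set: compound 1 sits at a 4.9-fold higher number from compound 1 to compound 3 (0.69 log units; beyond the scatter) distance from it, after isopropoxycarbonyl in place of hydrogen on an amine nitrogen in a ring, and compound 2, which gives 420 nM, lies far lower still.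

The next compound, compound 4, `CNC1=NC(C)=C(C(=O)OC)C(c2cccc([N+](=O)[O-])c2)N1C(=O)OC(C)C`, keeps everything in compound 3 except one group: methylamino in place of methylsulfanyl on a carbon with a double bond to nitrogen. This change is new to the set. Among the compounds with values here, the only measured step, from compound 1 to compound 3, concerns the isopropoxycarbonyl group and says nothing about what happens when the methylsulfanyl group is exchanged. Compounds 1 and 2 differ from each other in more than one place, so their values give no clean guide either. Within the data shown here, with no measured step bearing on this change, the expectation for compound 4 is a step of a 1.1-fold lower number from compound 3 to compound 4 (0.03 log units; within the scatter), that is, no change beyond the scatter, but with wide uncertainty on either side. Compound 4 is therefore estimated at 15000 nM in this assay, expected to fall between 3500 nM and 65000 nM.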

Compound 4, half-maximal inhibitory concentration: 1810 nM
Compound 4: the middle estimate sits 8.3-fold (0.92 log units) above what was measured; measured number outside the range, below it.
By their numbers in this assay, from the lowest: compound 2; then compounds 4 and 1 (each within the scatter of the next); then compound 3.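

In this assay, the carbon with a double bond to nitrogen, between two ring nitrogen atoms, turns out to be a place where the choice of group matters: methylamino in place of methylsulfanyl gives an 8.9-fold lower number from compound 3 to compound 4 (0.95 log units; beyond the scatter) and so a stronger inhibitor. Both groups have 2 heavy atoms, so the number moves beyond the scatter even though the heavy-atom count stays the same; the swap exchanges sulfur for nitrogen and brings in 1 hydrogen-bond donor. Nothing measured here explains the step or shows which of these differences matters.

From the compounds shown here alone, this single step was read only with the isopropoxycarbonyl group on the ring nitrogen, so whether the same exchange would lower the number in compound 1, which has hydrogen there instead, remains open. The compounds shown also leave open how a plain amine, a dimethylamino group or a longer chain such as ethylamino would compare with methylamino at this position.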